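The compounds below may be only part of what the source reports. "The series", "measured", "known", "first", "only" and "open" are said of these compounds alone.

Working notes on the series. For the measured compounds named here, compound 1 `COc1ccc(OC)c(/C=C/c2nnc(Nc3ccc(Cl)cc3)o2)c1` is the first member. In a functional assay on UACC-62 cells (Homo sapiens) for antiproliferative activity, read by sulforhodamine B assay, with a stated time of 48 h (on this read-out lower numbers stand for higher toxicity in this test and higher numbers for lower toxicity in this test), compound 1 gives > 100000 nM, which is a limit of the assay rather than a number. Compound 2 `COc1ccc(OC)c(/C=C/C(=O)N/N=C/c2ccc(Cl)cc2)c1` is the second member. In this assay compound 2 gives > 100000 nM, again a limit and not a number. Going by the values given here, compound 2 thus cannot be placed on a scale: only a limit exists for it, and the one other value shown is a limit too, so both results sit at the limit of > 100000 nM in this assay, at which 2 of the 2 values shown sit. Among the compounds with values here, no step between measured compounds that differ in one place exists, so nothing measured tells how a single change moves the read-out.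

Compound 3 `COc1ccc(OC)c(/C=C/C(=O)N/N=C/c2ccccc2)c1` is not yet measured. It differs from compound 2 by hydrogen in place of chloro on an aromatic carbon. Within the data shown here, with both measured values at the limit, no step of a particular size or direction is expected in this assay for this change, and none beyond the scatter. The expected step is a number no higher from compound 2 to compound 3 (the limit leaves the size open), essentially none. Compound 3 is therefore estimated at 100000 nM, with a range from 30000 nM to 300000 nM, and a high chance that only a limit is reported again.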

Compound 3, concentration lethal to 50% of the cells: > 100000 nM
Compound 3 gave a limit, no number (the forecaster's own chance of this, stated with the estimate: 75%); the middle value lies on the limit itself.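

In this assay compound 3 gives > 100000 nM as a limit and not a number. No step can be read between compound 2 and compound 3, and all results shown sit together: the limit of > 100000 nM in this assay, at which 3 of the 3 values shown sit. The compounds shown leave open whether the change from 4-chlorophenyl to phenyl, or any other change, moves the read-out in this assay at all.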